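A few compounds are considered here, and "the series" means these few. Any claim that something is new, unique, unknown or untested is made for them only; others in the source may bear on it.

Among the measured compounds shown here, in an assay on HEK293 cells for inhibition of Steryl-sulfatase (Homo sapiens), tested at 1 uM (on this read-out lower numbers stand for a weaker effect and higher numbers for a stronger effect at the one concentration tested), three members have numbers so far. Compound 1 `CN(CCCN1CCCCC1)c1cccc(C(=O)N2CCc3ccc(OS(N)(=O)=O)cc3C2)c1` gives 30.6%. Compound 2 `CC(C)CCN(CCC(C)C)c1cccc(C(=O)N2CCc3ccc(OS(N)(=O)=O)cc3C2)c1` gives 75.9%. Compound 3 `CCCN(Cc1ccccc1)c1cccc(C(=O)N2CCc3ccc(OS(N)(=O)=O)cc3C2)c1` gives 67.4% and stands with compound 2 at the upper end of the three: the nearest number is that of compound 2, a number 8.5 percentage points lower from compound 2 to compound 3 (within the scatter), while compound 1 is the furthest, a number 36.8 percentage points higher from compound 1 to compound 3 (beyond the scatter). The step of a number 45.3 percentage points higher from compound 1 to compound 2 (beyond the scatter) runs the same way.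

Compound 4 `CN(CCN1CCCCC1)c1cccc(C(=O)N2CCc3ccc(OS(N)(=O)=O)cc3C2)c1` carries methyl(2-(piperidin-1-yl)ethyl)amino in place of benzyl(propyl)amino on an aromatic carbon. For the measured compounds named here, two measured steps bear on this change. The step of a number 36.8 percentage points higher from compound 1 to compound 3 (beyond the scatter) is the reverse of the direction taken here, and the step of a number 45.3 percentage points higher from compound 1 to compound 2 (beyond the scatter) likewise moved away from a methyl(3-(piperidin-1-yl)propyl)amino group; both were large. A large downward step in this assay is therefore expected, a number 34.4 percentage points lower from compound 3 to compound 4 (beyond the scatter), because compound 1 gives 30.6% with a closely related piperidine-bearing amino group in the same place. For compound 4 the estimate is 33%, with a range from 15% to 55%.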

Compound 4, a percentage reported as inhibition, at one concentration (the size of the read-out at that concentration, not a potency): 30.8%
Compound 4: middle estimate off by 2.2 percentage points, on the high side; measured number inside the range.
By their numbers in this assay, from the lowest: compounds 1 and 4 (each within the scatter of the next); then compounds 3 and 2 (each within the scatter of the next).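

In this assay, the two piperidine-bearing groups stand level on the aromatic carbon, a number 0.2 percentage points higher from compound 1 to compound 4 (within the scatter), so this shorter chain and the propyl chain of compound 1 are not told apart by this read-out. The large gap to the groups without a piperidine ring also holds for the ethyl chain, a number 36.6 percentage points lower from compound 3 to compound 4 (beyond the scatter) and a number 45.1 percentage points lower from compound 2 to compound 4 (beyond the scatter), so it is not confined to the propyl form. Nothing available explains this gap.

As far as these compounds go, whether the low numbers go with the ring nitrogen or with the ring as a whole stays open; a cyclohexyl group in place of piperidin-1-yl on the same chain would separate the two. A butyl chain carrying the piperidine ring would show whether the level reading extends to a longer link.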